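A few compounds are considered here, and "the series" means these few. Any claim that something is new, unique, unknown or untested is made for them only; others in the source may bear on it.

Measured so far:
compound 1, `O=C(C1CCCCC1)N1CC(c2nc(-c3cccc(F)c3)no2)C1`, 1000 nM
compound 2, `O=C(c1ccc(F)c(F)c1)N1CC(c2nc(-c3cccc(F)c3)no2)C1`, 3200 nM

Among the measured compounds shown here, in an assay on HEK293 cells for positive allosteric modulation of metabotropic glutamate receptor 5 (Homo sapiens), read by FLIPR (a higher number here means that more compound is needed for the effect, a lower number that less compound is needed), compound 1 stands at the lower of the two numbers, with compound 2 the only neighbour. For the measured compounds named here, the single measured step is a 3.2-fold higher number from compound 1 to compound 2 (0.51 log units; beyond the scatter), a change of the whole group on the carbonyl carbon. Compound 3, `O=C(C1CCC(C(F)(F)F)CC1)N1CC(c2nc(-c3cccc(F)c3)no2)C1`, keeps that group and instead carries trifluoromethyl in place of hydrogen on a saturated ring carbon. Going by the values given here, no measured step touches this place, so the one step gives only a weak guide: the group on the carbonyl carbon matters, but how a substituent on the saturated ring acts is unknown. Compound 3 is therefore expected to stay near compound 1, with a step no larger than no change at the digits printed from compound 1 to compound 3 (within the scatter), in either direction. The estimate for compound 3 is 1000 nM, within 300 nM to 3500 nM.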

Compound 3, half-maximal effective concentration: 680 nM
Estimate against measurement, compound 3: 1.5-fold (0.17 log units) above, and the stated range covers the measured number.
By their numbers in this assay, from the lowest: compounds 3 and 1 (each within the scatter of the next); then compound 2.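

In this assay, trifluoromethyl in place of hydrogen on a saturated ring carbon, three ring bonds from the ring atom that bears a large group, gives a 1.5-fold lower number from compound 1 to compound 3 (0.17 log units; within the scatter) and so stays level with the parent. The earlier compounds shown here showed only an exchange of the whole group on the carbonyl carbon, not a substituent on this ring. Nothing available explains this result.

The compounds shown leave open how an amine, a hydroxyl or a carboxylic acid would behave at this ring carbon.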